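A Pyridin-2-yl Replaces the Methoxyphenyl: Expectation for Compound 4

The source may report more compounds than this note shows. Statements on the series, on what has been measured and on what is new or still open speak of the compounds shown alone.

Of the compounds shown here, three sharing one core have been tested in a functional assay on MCF7 cells (Homo sapiens) for antiproliferative activity, read by MTT assay, with a stated time of 72 h; on this read-out higher numbers stand for weaker inhibition and lower numbers for stronger inhibition. Compound 1 `COc1ccc(N2CCN(C(=S)SCc3ccc4nc(N)nc(N)c4c3)CC2)cc1` gives 1580 nM, the lowest number of the three. Compound 2 `Nc1nc(N)c2cc(CSC(=S)N3CCN(c4ccc(Cl)c(Cl)c4)CC3)ccc2n1` gives 2370 nM, and compound 3 `Nc1nc(N)c2cc(CSC(=S)N3CCN(c4ccc(C(F)(F)F)cc4)CC3)ccc2n1` gives 7400 nM. Compound 1 is thus nearest to compound 2 and furthest from compound 3.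

The compound not yet measured, compound 4 `Nc1nc(N)c2cc(CSC(=S)N3CCN(c4ccccn4)CC3)ccc2n1`, differs from compound 1 in one place: pyridin-2-yl in place of 4-methoxyphenyl on an amine nitrogen in a ring. For the measured compounds named here, every step so far measured among the three has also swapped the group on that same ring nitrogen. The step of a 1.5-fold higher number from compound 1 to compound 2 (0.18 log units; within the scatter) stays within the scatter, the step of a 4.7-fold higher number from compound 1 to compound 3 (0.67 log units; beyond the scatter) is a modest rise beyond it, and the step of a 3.1-fold higher number from compound 2 to compound 3 (0.49 log units; beyond the scatter) is also modest. Each exchange of this group has either left the number roughly where it was or raised it modestly; none has lowered it. Going by the values given here, no measured compound carries pyridin-2-yl, so nothing more specific can be read from the data. On this evidence the expected step in this assay is a 1.6-fold higher number from compound 1 to compound 4 (0.20 log units; within the scatter), a small to modest rise rather than a fall. Compound 4 is estimated to give 2500 nM, with a likely range from 1000 nM to 6500 nM.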

Compound 4, half-maximal inhibitory concentration: 5110 nM
Compound 4: middle estimate off by 2.0-fold (0.31 log units), on the low side; the measured number falls inside the stated range.
By their numbers in this assay, from the lowest: compounds 1 and 2 (each within the scatter of the next); then compounds 4 and 3 (each within the scatter of the next).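

In this assay, for the compounds shown here, pyridin-2-yl is the first group at this position whose aromatic ring holds a hetero atom, and it does not keep the number near that of the 4-methoxyphenyl group (a 3.2-fold higher number from compound 1 to compound 4 (0.51 log units; beyond the scatter)). It also stands apart from the 3,4-dichlorophenyl group (a 2.2-fold higher number from compound 2 to compound 4 (0.33 log units; beyond the scatter)) but not from the 4-(trifluoromethyl)phenyl group (a 1.4-fold lower number from compound 3 to compound 4 (0.16 log units; within the scatter)), so the four compounds now form a lower pair, compounds 1 and 2, and a higher pair, compounds 3 and 4. Nothing at hand explains why two such different groups as pyridin-2-yl and 4-(trifluoromethyl)phenyl land together.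

This change alters two things at once, removing the methoxy group and placing a nitrogen in the aromatic ring, so an unsubstituted phenyl group on the same ring nitrogen would be needed to separate the two. Pyridin-3-yl and pyridin-4-yl, or a 6-methoxypyridin-3-yl group that keeps the methoxy alongside the ring nitrogen, would further show whether the place of that nitrogen matters to the number.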